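Amino on the core and half-life in buffer

The source may hold more compounds than are shown below. What is called first, only, known or untested is meant among the compounds shown, and "the series" means these compounds.

The series rests on two cores. Compound 1 `Cc1ccccc1CNC(=O)n1cnc2ccccc21` and compound 3 `Cc1ccccc1CNC(=O)n1c(N)nc2ccccc21` share one, compound 2 `O=C(NCCCCc1ccccc1)n1cnc2ccccc21` and the unmeasured compound 4 `Nc1nc2ccccc2n1C(=O)NCCCCc1ccccc1` the other. The difference between the two cores is not broken down here.

In a physicochemical assay for metabolic stability, read by HPLC, in phosphate buffer, at pH 7.4, tested at 10 uM (on this read-out higher numbers stand for a longer-lived compound and lower numbers for a shorter-lived compound), compound 1 gives 0.967 h. Compound 2 gives 0.833 h; the gap between compound 1 and compound 2 lies within the scatter, so the two cores are not told apart on this read-out. Compound 3 gives 0.167 h.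

The change from compound 1 to compound 3 is amino in place of hydrogen on an aromatic carbon and brings a 5.8-fold lower number from compound 1 to compound 3 (0.76 log units; beyond the scatter). The change from compound 2 to compound 4 is amino in place of hydrogen on an aromatic carbon. The place of the entering amino is described in the same words for both pairs, so this is the same change made on the second core.

For the measured compounds named here, compound 2 and compound 1 sit within the scatter of each other, and the one measured instance of the change, from compound 1 to compound 3, is beyond the scatter. On that basis the step of a 5.6-fold lower number from compound 2 to compound 4 (0.74 log units; beyond the scatter) is expected, of about the size already seen for this change. Going by the values given here, only one instance of the change has been measured, so the width of the range is kept generous. Compound 4 is therefore estimated at 0.15 h, with a range from 0.07 h to 0.35 h.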

Compound 4, half-life: 0.233 h
The estimate for compound 4 lay 1.6-fold (0.19 log units) below the measured number; measured number inside the range.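

In this assay, amino in place of hydrogen on an aromatic carbon, between two ring nitrogen atoms, brings a 3.6-fold lower number from compound 2 to compound 4 (0.55 log units; beyond the scatter), while the same change on the other core brought a 5.8-fold lower number from compound 1 to compound 3 (0.76 log units; beyond the scatter). The change therefore carries from one core to the other in direction, with both steps beyond the scatter, but two pairs are too few to show a fixed step size or to support a rule for any further core. Nothing shown here explains why the number falls on either core.

The compounds shown leave open whether the fall belongs to amino itself or would also follow from another group at the same place, such as methyl, hydroxyl or dimethylamino. For the compounds shown here, they also leave open whether the step would hold with the side chain changed further, for example with a longer chain than the one in compound 2 or with a carboxylic acid at its end.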